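Swapping the ring-bearing amine of compound 3 for an open chain

A few compounds are considered here, and "the series" means these few. Any claim that something is new, unique, unknown or untested is made for them only; others in the source may bear on it.

Compound 3 `Cc1nc(N2CCC(N3CCNC3=O)CC2)nc2ccc(NC(=O)/C=C/c3ccc(OC(F)(F)F)cc3)cc12` stands highest of the three measured compounds in an ADME assay on microsomes from liver (Mus musculus) for metabolic stability, with a stated time of 30 min (a lower number here means that less of the compound is left, a higher number that more of the compound is left), where compound 3 gives 89%. Compound 1 `Cc1nc(N2CCC(N3CCOC3=O)CC2)nc2ccc(NC(=O)/C=C/c3ccc(OC(F)(F)F)cc3)cc12` gives 74% in this assay, and compound 2 `COCC(=O)NC1CCN(c2nc(C)c3cc(NC(=O)/C=C/c4ccc(OC(F)(F)F)cc4)ccc3n2)CC1` gives 57%. The steps of a number 15 percentage points higher from compound 1 to compound 3 (beyond the scatter) and a number 32 percentage points higher from compound 2 to compound 3 (beyond the scatter) set compound 3 apart from both, while a number 17 percentage points lower from compound 1 to compound 2 (beyond the scatter) separates the other two. Compound 4 `Cc1nc(NCCCNS(C)(=O)=O)nc2ccc(NC(=O)/C=C/c3ccc(OC(F)(F)F)cc3)cc12` differs from compound 3 by (3-(methanesulfonamido)propyl)amino in place of 4-(2-oxoimidazolidin-1-yl)piperidin-1-yl on an aromatic carbon. Among the measured compounds shown here, no measured step exchanges these two groups; the nearest comparison is a number 17 percentage points lower from compound 1 to compound 2 (beyond the scatter), where a group holding a ring gave way to one holding no ring and the number fell modestly. The change to compound 4 is broader, removing both rings at once, so a larger fall than that is expected, though with considerable uncertainty. Compound 4 is therefore estimated at 60% in this assay, within 35% to 85%. This expectation corresponds to a step of a number 29 percentage points lower from compound 3 to compound 4 (beyond the scatter).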

Compound 4, percent of the compound remaining: 58%
Estimate against measurement, compound 4: 2 percentage points above; low and high end bracket the measured number.
By their numbers in this assay, from the lowest: compounds 2 and 4 (each within the scatter of the next); then compound 1; then compound 3.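

In this assay the position proves sensitive to losing both rings, with a number 31 percentage points lower from compound 3 to compound 4 (beyond the scatter) when the open chain (3-(methanesulfonamido)propyl)amino enters. The same chain gives a number 16 percentage points lower from compound 1 to compound 4 (beyond the scatter) yet only a number 1 percentage points higher from compound 2 to compound 4 (within the scatter), so a group with no ring lies within the scatter of compound 2, which keeps its piperidine ring, and the removal of the piperidine ring alone does not appear to separate these compounds: compound 1 and compound 3, which carry a second five-membered ring, both stand clear of compound 2 and compound 4. No evidence is available to explain these differences.

Which part of the change carries the fall stays open, as the ring loss and the entry of the methanesulfonamido group come together in compound 4. Going by these compounds, how a longer chain, or a terminal primary amine or carboxylic acid in place of the methanesulfonamido group, would read at this position also remains open.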